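This account rests on a few compounds, and the source may have more. Where it says the series, first, only, none or still open, it means among the compounds named here.

Measured in a physicochemical assay for lipophilicity, at pH 7.4; on this read-out lower numbers stand for lower lipophilicity and higher numbers for higher lipophilicity:
- compound 1 `Cc1cc(NC(=O)CC(C)(C)C)nn1Cc1cc(Cl)ccc1OCc1ccccc1`: > 3.7 (a limit)
- compound 2 `Cc1cc(NC(=O)c2c(F)cccc2F)nn1Cc1cc(Cl)ccc1OCc1ccccc1`: > 3.7 (a limit)

Compound 2 gives > 3.7, which is a limit of the assay and not a number. The series therefore stands at the limit of > 3.7 in this assay, at which 2 of the 2 values shown sit, and compound 2 cannot be placed more closely than that.

The next compound is compound 3 `Cc1cc(NC(=O)OCC(C)C)nn1Cc1cc(Cl)ccc1OCc1ccccc1`. It keeps the shared core and carries isobutoxy in place of 2,6-difluorophenyl on a carbonyl carbon.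

Among the compounds with values here, the one measured step at this place is a step that the two limits leave unreadable from compound 1 to compound 2, with 2,6-difluorophenyl in place of neopentyl. It gives neither a size nor a direction to carry over. No step beyond the usual scatter is therefore expected in this assay, and this is a weak expectation, resting on limits alone. The expected change is a step that the limit leaves unreadable from compound 2 to compound 3, an estimate and not a measured step. Another report as a limit would be no surprise.

For compound 3 the estimated value is 3.9, with an expected range from 3.4 to 4.5.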

Compound 3, distribution coefficient: 3.3
Compound 3: middle estimate off by 0.60 log units, on the high side, and the stated range ends above it.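

In this assay, the carbonyl carbon bonded to the amide-type nitrogen now proves to be a place where a change can bring the series off the assay limit, which the earlier compounds could not show: the limit of > 3.7 in this assay, at which 2 of the 3 values shown sit.

Isobutoxy in place of 2,6-difluorophenyl gives a number at least 0.40 log units lower from compound 2 to compound 3 (beyond the scatter), and isobutoxy in place of neopentyl gives a number at least 0.40 log units lower from compound 1 to compound 3 (beyond the scatter); both steps are beyond the scatter, and each is readable only as a minimum size. Compound 1 also has no ring at this place and still reports only a limit, so having no ring there is not enough on its own to give a measurable value.

The full size of each step stays open, and the compounds shown do not separate the oxygen of isobutoxy from the other features of that group. Also open, on these data alone, is how the read-out would respond at this carbonyl carbon to a longer alkoxy chain, a dimethylamino group or a carboxylic acid carried on a short chain.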